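The compounds below may be only part of what the source reports. "The series", "measured", "known", "first", "only" and "open" are said of these compounds alone.

Measured compounds in an assay on tissue (HeLa cells) for inhibition of Indoleamine 2,3-dioxygenase 1 (Homo sapiens), read by spectrophotometry; on this read-out lower numbers stand for stronger inhibition and higher numbers for weaker inhibition:
compound 1, `O/N=C(/Nc1cccc(F)c1)c1ccc2occc2c1`, gives 20000 nM;
compound 2, `O/N=C(/Nc1ccc(Cl)c(F)c1)c1ccc2occc2c1`, gives 10300 nM;
compound 3, `O/N=C(/NCc1ccccc1)c1ccc2occc2c1`, gives 28200 nM.

Compound 1 and compound 2 differ by chloro in place of hydrogen on an aromatic carbon, and this step gave a 1.9-fold lower number from compound 1 to compound 2 (0.29 log units; within the scatter). Compound 3 carries a core that differs from the core of compound 1; the difference between the two cores is not broken down here, and their values in this assay lie within the scatter of each other, while compound 3 stands beyond the scatter from compound 2.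

Compound 4, `O/N=C(/NCc1cccc(Cl)c1)c1ccc2occc2c1`, is not yet measured. It differs from compound 3 by chloro in place of hydrogen on an aromatic carbon. Going by the values given here, this is the same kind of change as the one from compound 1 to compound 2, not the same change: there the chloro entered "ortho to a fluoro group (1 heavy atom); para to a large group", here it enters "meta to a large group". Because the step of a 1.9-fold lower number from compound 1 to compound 2 (0.29 log units; within the scatter) was small, the account expects a step of similar size, a 1.6-fold lower number from compound 3 to compound 4 (0.19 log units; within the scatter), from compound 3 to compound 4. Compound 4 is therefore estimated at 18000 nM in this assay.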

Compound 4, half-maximal inhibitory concentration: 5800 nM
Compound 4: the middle estimate sits 3.1-fold (0.49 log units) above what was measured; the whole stated range lies above it.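

In this assay, going by these compounds alone, the change from phenyl to 3-chlorophenyl gave a 4.9-fold lower number from compound 3 to compound 4 (0.69 log units; beyond the scatter) and moved the number in the same direction as the earlier chloro step, although only this new step lies beyond the scatter. Set side by side, the two steps cannot be told apart: the same change on two cores in this assay, a 1.9-fold lower number (0.29 log units; within the scatter) from compound 1 to compound 2 and a 4.9-fold lower number (0.69 log units; beyond the scatter) from compound 3 to compound 4, 2.5-fold (0.40 log units) apart, within the scatter of two such steps. The direction therefore held on both cores in these two pairs, but this does not show that the core alters or leaves unaltered the size of the step, and the chloro enters at a different place in each pair, so two pairs cannot separate the effect of the core from that of the place.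

The compounds shown leave open whether bromo, methyl or methoxy meta to a large group would give a step like that of chloro. They also leave open how compound 4 would respond to a longer chain leading to the ring, or to an amine or a carboxylic acid on that ring.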